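A few compounds are considered here, and "the series" means these few. Any claim that something is new, unique, unknown or untested is made for them only; others in the source may bear on it.

In an ADME assay on MT4 cells (Homo sapiens) for cytotoxicity (a lower number here means that less compound is tolerated, a higher number that more compound is tolerated), compound 1 `O=C(NC(=S)Nc1cccc(C(F)(F)F)c1)c1ccccc1` is recorded only as a limit, > 100000 nM. Compound 2 `FC(F)(F)c1cccc(NC(=S)Nc2ccc(Cl)cc2)c1` gives 6800 nM. Compound 3 `O=[N+]([O-])c1ccc(NC(=S)Nc2cccc(C(F)(F)F)c2)cc1` gives 9200 nM, which lies within the scatter of the value for compound 2, so these two numbers cannot be ranked. Compound 4 `N#Cc1ccc(NC(=S)Nc2cccc(C(F)(F)F)c2)cc1` differs from compound 2 as follows: cyano in place of chloro on an aromatic carbon. It has cyano in place of chloro on an aromatic carbon, para to a large group. Among the compounds with values here, the one measured step that bears on this change is also a replacement of chloro, by nitro: a 1.4-fold higher number from compound 2 to compound 3 (0.13 log units; within the scatter). That step stays within the scatter, so no step beyond the scatter is expected in this assay. The expected step is a 1.2-fold higher number from compound 2 to compound 4 (0.07 log units; within the scatter). Compound 4 is estimated at 8000 nM, with an expected range of 3500 nM to 20000 nM.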

Compound 4, half-maximal cytotoxic concentration: 7000 nM
Compound 4: the middle estimate sits 1.1-fold (0.06 log units) above what was measured, and the stated range covers the measured number.
By their numbers in this assay, from the lowest: compounds 2, 4 and 3 (each within the scatter of the next). At a limit, above all of these: compound 1.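

In this assay, cyano on this aromatic carbon, para to a large group, cannot be told apart from chloro (a 1.0-fold higher number from compound 2 to compound 4 (0.01 log units; within the scatter)) or from nitro (a 1.3-fold lower number from compound 3 to compound 4 (0.12 log units; within the scatter)). Within the data shown here, three different groups at this place now give values within the scatter of one another, where the earlier compounds offered only a single such pair. Nothing at hand accounts for this closeness. From the compounds shown here alone, it remains open whether an amine or a carboxylic acid at this place would stay within the same scatter, or whether a change elsewhere on the shared core would matter more.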